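Exchanging one fluorinated group on the weakest compound so far

A few compounds are considered here, and "the series" means these few. Any claim that something is new, unique, unknown or untested is made for them only; others in the source may bear on it.

Within the data shown here, in a functional assay on LNCaP cells (Homo sapiens) for antiproliferative activity, read by propidium iodide staining, with a stated time of 96 h (on this read-out higher numbers stand for weaker inhibition and lower numbers for stronger inhibition), three compounds have numbers so far. Compound 1 `CC(O)(CSc1ccc(S(F)(F)(F)(F)F)cc1)C(=O)Nc1ccc([N+](=O)[O-])cc1C(F)(F)F` gives 10300 nM in this read-out and compound 3 `CC(O)(CSc1ccccc1C(F)(F)F)C(=O)Nc1ccc(S(F)(F)(F)(F)F)cc1` gives 12300 nM there, two values within the scatter of each other. Compound 2 `CC(O)(CSc1cccc(S(F)(F)(F)(F)F)c1)C(=O)Nc1ccc(S(F)(F)(F)(F)F)cc1` stands highest at 25000 nM on this scale, which makes it the weakest inhibitor of the three, and its gap to each of the others lies beyond the scatter.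

Compound 4 `CC(O)(CSc1cccc(OC(F)(F)F)c1)C(=O)Nc1ccc(S(F)(F)(F)(F)F)cc1` has not yet been measured. It differs from compound 2 by a group of 5 heavy atoms (1 carbon, 1 oxygen, 3 fluorine; no ring) in place of a group of 6 heavy atoms (5 fluorine, 1 sulfur; no ring), on an aromatic carbon with trifluoromethoxy entering on an aromatic carbon of a six-membered aromatic ring of carbon only, meta to a large group. Among the measured compounds shown here, no measured pair shows this exchange or any other single change, so its effect cannot be read directly from the data. For the measured compounds named here, the only guide is that compound 2 at 25000 nM lies at the top of a short span, with compound 3 lower at 12300 nM in the same read-out. The expected result is a small move towards stronger inhibition, a 1.5-fold lower number from compound 2 to compound 4 (0.17 log units; within the scatter) in this assay and probably not beyond the scatter. Compound 4 is expected at 17000 nM within an estimated range of 8000 nM to 36000 nM in this read-out.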

Compound 4, half-maximal inhibitory concentration: 12800 nM
Compound 4: middle estimate off by 1.3-fold (0.12 log units), on the high side; low and high end bracket the measured number.
By their numbers in this assay, from the lowest: compounds 1, 3, 4 and 2 (each within the scatter of the next, the first and the last beyond it).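

In this assay, putting trifluoromethoxy in place of the group of 6 heavy atoms (5 fluorine, 1 sulfur), on an aromatic carbon of a six-membered aromatic ring of carbon only, meta to a large group, gives a 2.0-fold lower number from compound 2 to compound 4 (0.29 log units; within the scatter). Among these compounds, this is the first pair that differs in one place only, and it shows that at this position the two fluorinated groups cannot be told apart in this read-out, a direct comparison that the earlier compounds, each differing from the others in more than one place, could not provide. No measurement of any property of either group is available to bear on this result.

The compounds shown leave open how this position responds to a group of a different kind, such as an amine, a carboxylic acid or a longer alkyl chain, any of which would test whether the read-out moves beyond the scatter here at all. They also leave open whether the same exchange of fluorinated groups would give a similar step at another place on the shared core.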